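The source may hold more compounds than are shown below. What is called first, only, known or untested is meant among the compounds shown, and "the series" means these compounds.

Of the compounds shown here, three sharing one core have been measured in a functional assay on SK-MEL-28 cells (Homo sapiens) for cytotoxicity, read by MTT assay, with a stated time of 3 days; a lower number here means a stronger inhibitor, a higher number a weaker inhibitor. Compound 1 (`N#Cc1c(O)nc(SCc2nc3ccccc3[nH]2)nc1-c1ccccc1`) gives 7.7 nM. Compound 2 (`CN1CCN(c2nc(SCc3nc4ccccc4[nH]3)nc(-c3ccccc3)c2C#N)CC1`) gives 20 nM, which is a 2.6-fold higher number from compound 1 to compound 2 (0.41 log units; beyond the scatter). Compound 3 (`N#Cc1c(-c2ccccc2)nc(SCc2nc3ccccc3[nH]2)nc1N1CCN(S(=O)(=O)c2ccccc2)CC1`) gives 6.41 nM, and that value lies within the scatter of compound 1, so the two stand level, while compound 2 stands apart from both.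

Compound 4 (`N#Cc1c(-c2ccccc2)nc(SCc2nc3ccccc3[nH]2)nc1N1CCN(S(=O)(=O)c2ccccc2[N+](=O)[O-])CC1`) keeps everything in compound 3 except one change, (nitro in place of hydrogen on an aromatic carbon), which turns phenylsulfonyl into (2-nitrophenyl)sulfonyl. The closest evidence is the step that brought in the phenylsulfonyl group, a 3.1-fold lower number from compound 2 to compound 3 (0.49 log units; beyond the scatter), a modest move at the same amine nitrogen. Among the measured compounds shown here, no measured compound carries a substituent on that phenyl ring, so the data give no direction for the nitro group. Both measured steps were modest, and neither speaks directly to this change. The step estimated in this assay is a 1.2-fold higher number from compound 3 to compound 4 (0.10 log units; within the scatter), so none beyond the scatter is expected. Compound 4 is estimated at 8 nM, with an expected range of 3 nM to 22 nM.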

Compound 4, half-maximal inhibitory concentration: 8.9 nM
Compound 4: middle estimate off by 1.1-fold (0.05 log units), on the low side; the range from low to high includes it.
By their numbers in this assay, from the lowest: compounds 3, 1 and 4 (each within the scatter of the next); then compound 2.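

In this assay, among the compounds shown here, a substituent on the phenyl ring of the phenylsulfonyl group appears for the first time, and nitro in place of hydrogen gives a 1.4-fold higher number from compound 3 to compound 4 (0.14 log units; within the scatter), so this change leaves compound 4 level with compound 3. The (2-nitrophenyl)sulfonyl group also keeps the separation from the methyl group on the same amine nitrogen, with a 2.2-fold lower number from compound 2 to compound 4 (0.35 log units; beyond the scatter), so the gain seen with phenylsulfonyl survives this substitution. No measurement at hand bears on why the nitro group makes so little difference here.

As far as these compounds go, with only one substituent at one place on this ring, it remains open whether an amine or a methoxy group there, or a nitro group elsewhere on the ring, would stay level as well. From the compounds shown here alone, whether a carbonyl in place of the sulfonyl would hold the number at this level is also open.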